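Chloro in Place of Methoxy on the Triazole Aryl Group

This account rests on a few compounds, and the source may have more. Where it says the series, first, only, none or still open, it means among the compounds named here.

The study follows three measured compounds in an ADME assay on HEK293 cells (Homo sapiens) for cytotoxicity, read by MTT assay, with a stated time of 48 h; a lower number here means a stronger inhibitor, a higher number a weaker inhibitor. Compound 1 `CC1(C)CCC[C@]1(C)c1ccc(C=O)cc1` gives 771000 nM. Compound 2 `C=C1CCC[C@]2(C)CCC(c3cn(-c4ccc(OC)cc4)nn3)=CC[C@@]12C` gives 410000 nM, and compound 3 `C=C1CCC[C@]2(C)CCC(c3cn(-c4ccc(C(C)=O)cc4)nn3)=CC[C@@]12C` gives 520000 nM. For the measured compounds named here, compound 2 therefore stands among numbers that all lie within the scatter of one another: the only single-point step, a 1.3-fold higher number from compound 2 to compound 3 (0.10 log units; within the scatter), changes nothing beyond the scatter, and the gap between compound 2 and compound 1 is likewise within the scatter.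

Compound 4 `C=C1CCC[C@]2(C)CCC(c3cn(-c4ccc(Cl)cc4)nn3)=CC[C@@]12C` has not yet been measured. It differs from compound 2 by chloro in place of methoxy on an aromatic carbon. Going by the values given here, no measured step exchanges a methoxy for a chloro. Among the compounds with values here, the one step that alters this same position, a 1.3-fold higher number from compound 2 to compound 3 (0.10 log units; within the scatter), places an acetyl there and stays within the scatter, and the three measured compounds together span a range that is itself within the scatter. The step from compound 2 to compound 4 is therefore expected to be a 1.0-fold higher number from compound 2 to compound 4 (0.02 log units; within the scatter), that is, none beyond the scatter in either direction. Compound 4 is accordingly estimated at 430000 nM, with a range from 200000 nM to 900000 nM in this assay.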

Compound 4, half-maximal inhibitory concentration: 609000 nM
Compound 4: middle estimate off by 1.4-fold (0.15 log units), on the low side; measured number inside the range.
By their numbers in this assay, from the lowest: compounds 2, 3, 4 and 1 (each within the scatter of the next).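

With compound 4, this aromatic carbon, para to a large group, has now carried methoxy, acetyl and chloro, and in this assay the exchange of methoxy for chloro reads as a 1.5-fold higher number from compound 2 to compound 4 (0.17 log units; within the scatter) while the exchange of acetyl for chloro reads as a 1.2-fold higher number from compound 3 to compound 4 (0.07 log units; within the scatter) and so neither step leaves the scatter. Where the earlier compounds offered a single exchange at this place, the assay now fails to separate any of the three groups, even though chloro brings one heavy atom and no hydrogen-bond acceptor where methoxy brings two heavy atoms and one such acceptor. No supporting measurement bears on why these compounds read alike.

From the compounds shown here alone, whether a group of another kind on this carbon, such as an amine, a carboxylic acid or a longer alkyl chain, would take the number beyond the scatter remains open. Also open, going by these compounds, is whether methoxy, acetyl or chloro would read the same on another carbon of this ring, since all three sit at the same place on the shared core.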